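Swapping a hydroxyphenyl for a chlorophenyl on the urea end

The compounds below may be only part of what the source reports. "The series", "measured", "known", "first", "only" and "open" are said of these compounds alone.

Compound 3 `COc1cc(NC(C)CCCNC(=O)NNC(=O)Nc2ccc(O)cc2)c2ncccc2c1` gives 85000 nM in a functional assay on HeLa cells (Homo sapiens) for inhibition, read by MTT assay, with a stated time of 72 h (on this read-out higher numbers stand for weaker inhibition and lower numbers for stronger inhibition), the highest of the three numbers; compound 2 `COc1cc(NC(C)CCCNC(=O)Nc2ccc(O)cc2)c2ncccc2c1` gives 70000 nM, within the scatter of it, while compound 1 `COc1cc(NC(C)CCCNC(=O)Nc2ccc(C(F)(F)F)cc2)c2ncccc2c1` gives 8300 nM, a step of a 10-fold higher number from compound 1 to compound 3 (1.01 log units; beyond the scatter). Compound 4 `COc1cc(NC(C)CCCNC(=O)NNC(=O)Nc2cccc(Cl)c2)c2ncccc2c1` differs from compound 3 in one place: 3-chlorophenyl in place of 4-hydroxyphenyl on an amide-type nitrogen. The measured step that bears on this is an 8.4-fold higher number from compound 1 to compound 2 (0.93 log units; beyond the scatter), where a hydroxy group took the place of a trifluoromethyl group on an aromatic carbon and inhibition became weaker. Compound 4 removes that hydroxy group again, so a step toward stronger inhibition is expected, of size a 4.3-fold lower number from compound 3 to compound 4 (0.63 log units; beyond the scatter). Compound 4 is therefore estimated at 20000 nM, with a range from 6000 nM to 60000 nM.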

Compound 4, half-maximal inhibitory concentration: 44000 nM
The estimate for compound 4 lay 2.2-fold (0.34 log units) below the measured number; the range from low to high includes it.
By their numbers in this assay, from the lowest: compound 1; then compounds 4, 2 and 3 (each within the scatter of the next).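

In this assay, the step of a 1.9-fold lower number from compound 3 to compound 4 (0.29 log units; within the scatter) lies within the scatter, so removing the hydroxy group here does not clearly strengthen inhibition as the step between compound 1 and compound 2 suggested. The step of a 1.6-fold lower number from compound 2 to compound 4 (0.20 log units; within the scatter) is also within the scatter, whereas a 5.3-fold higher number from compound 1 to compound 4 (0.72 log units; beyond the scatter) lies beyond it, leaving compound 1 the strongest of the four. No supporting measurement is available to explain these results.

Still open, on these data alone, is how a plain phenyl or a 4-chlorophenyl would read on this amide-type nitrogen, which would separate the effect of the chlorine from that of where it sits.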